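Ring closure at the aminoquinoline of a hormone receptor agonist series

The source may report more compounds than this note shows. Statements on the series, on what has been measured and on what is new or still open speak of the compounds shown alone.

Among the compounds with values here, compound 1 `CN(c1ccc2cc(NC(=O)CCc3ccc(C(F)(F)F)cc3)ccc2n1)C1CCCCC1` is the only member of the set with a single number of its own: in a functional assay on HEK293 cells for activation of melanin-concentrating hormone receptor 1 (Rattus norvegicus), read by inositol phosphate accumulation (on this read-out higher numbers stand for an effect only at larger amounts of compound and lower numbers for an effect already at smaller amounts), compound 1 gives 1200 nM. Compound 2 `O=C(CCc1ccc(C(F)(F)F)cc1)Nc1ccc2nc(N3CCCC3)ccc2c1`, carrying the same amide, gives 320 nM; 320 nM (2 entries) in this assay. Compound 3 `O=C(CCc1ccc(C(F)(F)F)cc1)Nc1ccc2nc(N3CCCCCC3)ccc2c1` arises from compound 1 by the change (azepan-1-yl in place of cyclohexyl(methyl)amino on an aromatic carbon). Because compound 2 gives 320 nM; 320 nM (2 entries) with a smaller ring at the same place, a step of a 2.4-fold lower number from compound 1 to compound 3 (0.38 log units; beyond the scatter) towards lower values is expected, though within a modest size. Compound 3 is therefore estimated at 500 nM, ranging from 150 nM to 2000 nM.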

Compound 3, half-maximal effective concentration: 1800 nM
Compound 3: the middle estimate sits 3.6-fold (0.56 log units) below what was measured; measured number inside the range.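

In this assay, azepan-1-yl in place of cyclohexyl(methyl)amino gives a 1.5-fold higher number from compound 1 to compound 3 (0.18 log units; within the scatter), so the two groups cannot be told apart at this position. Closing the amine into a ring is thus not enough by itself to reach the level of compound 2: compound 2 gives 320 nM; 320 nM (2 entries) and compound 3 gives 1800 nM. The data shown offer no explanation for this result. The compounds shown leave open how piperidin-1-yl or morpholin-4-yl would read at this place, and whether the number follows ring size across more than these two rings.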